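Dichlorophenyl Thioether Gives Way to a Fluorophenoxy Group

The compounds below may be only part of what the source reports. "The series", "measured", "known", "first", "only" and "open" are said of these compounds alone.

Compound 1, `Nc1cc(N)c2nc(-c3ccccc3)c(Oc3ccc(Cl)c(Cl)c3)nc2c1`, in a functional assay on NCI-H522 cells (Homo sapiens) for inhibition, read by sulforhodamine B assay, with a stated time of 48 h (a higher number here means that more compound is tolerated, a lower number that less compound is tolerated), gives < 100000 nM.
Compound 2, `Nc1cc(N)c2nc(-c3ccccc3)c(Sc3ccc(Cl)c(Cl)c3)nc2c1`, in this assay gives < 100000 nM.

Both of these values are limits of the assay rather than numbers, so compound 2 stands only at a limit, and the step that the two limits leave unreadable from compound 1 to compound 2 cannot be read. The change to compound 3, `Nc1cc(N)c2nc(-c3ccccc3)c(Oc3ccc(F)cc3)nc2c1`, is 4-fluorophenoxy in place of (3,4-dichlorophenyl)sulfanyl on an aromatic carbon. Among the compounds with values here, no measured step bears readably on this change; all that is known is the limit of < 100000 nM in this assay, at which 2 of the 2 values shown sit. The expected step that the limit leaves unreadable from compound 2 to compound 3 therefore rests on no measured pattern. Compound 3 is estimated at 50000 nM, in the range 10000 nM to 200000 nM.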

Compound 3, concentration lethal to 50% of the cells: < 100000 nM
Compound 3: no number, only a limit (the forecaster's own chance of this, stated with the estimate: 60%); the middle value is on the limit's open side.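

Within the data shown here, compound 3 gives < 100000 nM, which is a limit and not a number, so no step from compound 1 or compound 2 to compound 3 can be read. The compounds shown leave open whether these group changes make any difference in this assay.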